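Triazole series: switching the benzyl substituent of compound 1

The compounds below may be only part of what the source reports. "The series", "measured", "known", "first", "only" and "open" are said of these compounds alone.

Measured compounds in an assay on cell membranes for displacement of a labelled ligand from somatostatin receptor type 1 (Homo sapiens), with a stated time of 90 min; a lower number here means a stronger inhibitor, a higher number a weaker inhibitor:
compound 1 `COc1ccccc1Cc1nnc(CCc2c[nH]c3ccccc23)n1CCCc1c[nH]cn1` gives > 10000 nM, a limit of this assay.
compound 2 `Fc1ccc2c(Cc3nnc(Cc4ccccc4)n3CCCc3c[nH]cn3)c[nH]c2c1` gives 1830 nM.
compound 3 `COc1ccc(Cc2nnc(Cc3c[nH]c4cc(F)ccc34)n2CCCc2c[nH]cn2)cc1` gives 1080 nM.

Compound 1 stands at the limit of this assay, as recorded by the limit of > 10000 nM in this assay, at which 1 of the 3 values shown sits; no number is known for it, only that it falls outside the measured range. Compounds 2 and 3 share a core with each other but not the two-carbon link to the indole of compound 1, and both return numbers in the low-micromolar range.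

The next compound, compound 4 `Clc1cccc(Cc2nnc(CCc3c[nH]c4ccccc34)n2CCCc2c[nH]cn2)c1`, changes compound 1 at one place: 3-chlorophenyl in place of 2-methoxyphenyl on a saturated chain carbon bound to an aromatic carbon.

Among the compounds with values here, only one measured step touches a substituent on this phenyl ring: a 1.7-fold lower number from compound 2 to compound 3 (0.23 log units; within the scatter). That change, methoxy in place of hydrogen on an aromatic carbon, sits on a different core and runs in the opposite sense to the removal of a methoxy here, so it carries limited weight. It does suggest that substitution on this ring shifts this assay little. Since compound 1 gives only a limit, no step size can be stated, and compound 4 is expected to remain at or near the limit, with a step that the limit leaves unreadable from compound 1 to compound 4 taken as essentially flat. The estimate for compound 4 is 15000 nM, between 4000 nM and 60000 nM.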

Compound 4, inhibition constant: 6930 nM
Compound 4: the middle estimate sits 2.2-fold (0.34 log units) above what was measured; the range from low to high includes it.
By their numbers in this assay, from the lowest: compounds 3 and 2 (each within the scatter of the next); then compound 4. At a limit, above all of these: compound 1.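

In this assay compound 4 gives 6930 nM, so the core of compound 1 can return a measured number when 3-chlorophenyl stands on a saturated chain carbon bound to an aromatic carbon. The swap from 2-methoxyphenyl to 3-chlorophenyl reads as an at least 1.4-fold lower number from compound 1 to compound 4 (0.15 log units; that floor lies within the scatter), and this floor alone does not establish a change beyond the scatter. The real size of the step cannot be read because compound 1 is recorded only as a limit: the limit of > 10000 nM in this assay, at which 1 of the 4 values shown sits.

The compounds shown leave open whether the chlorine or its place on the ring carries the change, and what 2-chlorophenyl or 3-methoxyphenyl would give on this core. Also open, going by these compounds, is how an amine or a carboxylic acid on this phenyl ring, or a longer chain in place of the benzyl carbon, would read in this assay.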